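A Benzyl Group Replaces Cyclopropyl on the Core

A few compounds are considered here, and "the series" means these few. Any claim that something is new, unique, unknown or untested is made for them only; others in the source may bear on it.

Among the compounds with values here, compound 1 `CN1C(=O)C(C2CC2)N(C)c2nc(Nc3ccc(S(N)(=O)=O)cc3)ncc21` is one of three compounds measured in an assay on Sf9 cells for inhibition of serine/threonine-protein kinase 4 (Homo sapiens), read by luminescence and ADP-Glo, with a stated time of 1 h, in the presence of a further agent that is not named here (a lower number here means a stronger inhibitor, a higher number a weaker inhibitor), where compound 1 gives 136 nM. Among those three numbers it stands second highest. Compound 3 `CN1C(=O)C(c2ccccc2Br)N(C)c2nc(Nc3ccc(S(N)(=O)=O)cc3)ncc21` gives 57 nM in this assay, and compound 2 `COc1cccc(C2C(=O)N(C)c3cnc(Nc4ccc(S(N)(=O)=O)cc4)nc3N2C)c1` gives 954 nM. Compound 4 `CN1C(=O)C(Cc2ccccc2)N(C)c2nc(Nc3ccc(S(N)(=O)=O)cc3)ncc21` has not yet been measured; it differs from compound 1 in one place: benzyl in place of cyclopropyl on a saturated ring carbon.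

Within the data shown here, two measured steps bear on this change, since each also replaces the cyclopropyl on the same saturated ring carbon with a group built on a six-membered aromatic ring of carbon. The change to 3-methoxyphenyl gave a 7.0-fold higher number from compound 1 to compound 2 (0.85 log units; beyond the scatter), a weaker inhibitor, while the change to 2-bromophenyl gave a 2.4-fold lower number from compound 1 to compound 3 (0.38 log units; beyond the scatter), a stronger one. The benzyl of compound 4 is neither of those groups, and the two steps point in opposite directions, so neither is a close match. A step of modest size in either direction is therefore plausible, and the estimate is centred close to the value of compound 1, with a wide range to cover both outcomes. Compound 4 is expected to give 200 nM, between 60 nM and 700 nM, which means an expected 1.5-fold higher number from compound 1 to compound 4 (0.17 log units; within the scatter).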

Compound 4, half-maximal inhibitory concentration: > 10000 nM
Compound 4: no number, only a limit (the forecaster's own chance of this, stated with the estimate: 3%); middle value at least 50-fold (1.69 log units) away from the limit.
By their numbers in this assay, from the lowest: compound 3; then compound 1; then compound 2. At a limit, above all of these: compound 4.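

In this assay, compound 4 gives no number, only a limit of the assay: the limit of > 10000 nM in this assay, at which 1 of the 4 values shown sits.

Even read against that limit, benzyl in place of cyclopropyl gives an at least 73-fold higher number from compound 1 to compound 4 (1.86 log units; beyond the scatter), benzyl in place of 2-bromophenyl gives an at least 170-fold higher number from compound 3 to compound 4 (2.24 log units; beyond the scatter), and benzyl in place of 3-methoxyphenyl gives an at least 10-fold higher number from compound 2 to compound 4 (1.02 log units; beyond the scatter). The earlier compounds shown here showed that changes at this saturated ring carbon could move the number modestly in either direction from compound 1, or by a large step between compound 2 and compound 3, yet all three gave measurable numbers. Compound 4 adds that this position can also lose measurable inhibition altogether, and that carrying a six-membered aromatic ring of carbon does not by itself decide the outcome, as compound 2, compound 3 and compound 4 all carry one.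

The compounds shown leave open whether the methylene link of the benzyl or the unsubstituted ring matters more, a question that a plain phenyl group would help to separate. They also leave open how a small open chain such as ethyl, or a group carrying an amine, would behave at this carbon.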